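A few compounds are considered here, and "the series" means these few. Any claim that something is new, unique, unknown or untested is made for them only; others in the source may bear on it.

The shared core of compound 1 `COc1ccc(-n2nc(C(N)=O)nc2-c2cc(OC)c(OC)c(OC)c2)cc1` carries a primary amide, and in a functional assay on the whole organism for inhibition, with Rattus norvegicus as the target, read by paw edema, with stated times of 30 min and 5 h, at a dose of 0.28 mmol/kg by the oral route (a higher number here means more inhibition at the dose given (going by the name of the read-out), a lower number less inhibition), compound 1 gives 64%. Compound 2 `CNC(=O)c1nc(-c2cc(OC)c(OC)c(OC)c2)n(-c2ccc(OC)cc2)n1` has a methyl on the amide nitrogen and in this assay compound 2 gives 50%. Compound 3 `COc1ccc(-n2nc(C(=O)Nc3cccc(F)c3)nc2-c2cc(OC)c(OC)c(OC)c2)cc1` bears a 3-fluorophenyl there, and in this assay compound 3 gives 53%. Compound 2 thus sits a number 14 percentage points lower from compound 1 to compound 2 (beyond the scatter), while its separation from compound 3 is a number 3 percentage points higher from compound 2 to compound 3 (within the scatter). Compound 4 `COc1ccc(-n2nc(C(=O)Nc3ccccc3)nc2-c2cc(OC)c(OC)c(OC)c2)cc1` is built from compound 2 by the change (phenyl in place of methyl on an amide-type nitrogen). The step that bears most on it is a number 3 percentage points higher from compound 2 to compound 3 (within the scatter), an aryl group entering at the same nitrogen; the parallel step a number 11 percentage points lower from compound 1 to compound 3 (beyond the scatter) shows that the unsubstituted amide stands apart, but compound 4 does not start from it. Compound 4 is therefore expected to stay near compound 2, with the step estimated as a number 2 percentage points higher from compound 2 to compound 4 (within the scatter). In this assay compound 4 is estimated at 52%, within a range from 42% to 62%.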

Compound 4, a percentage reported as inhibition, in the whole organism at one dose (the size of the read-out at that dose, not a potency): 46%
Beside the measured number, compound 4's estimate is 6 percentage points above it; the measured number falls inside the stated range.
By their numbers in this assay, from the lowest: compounds 4, 2 and 3 (each within the scatter of the next); then compound 1.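

In this assay, a phenyl on the amide-type nitrogen cannot be told apart from a methyl there (a number 4 percentage points lower from compound 2 to compound 4 (within the scatter)), and hydrogen in place of fluoro on the aromatic ring also stays within the scatter (a number 7 percentage points lower from compound 3 to compound 4 (within the scatter)). Against the primary amide the phenyl gives a clear drop (a number 18 percentage points lower from compound 1 to compound 4 (beyond the scatter)), so methyl, phenyl and 3-fluorophenyl on this nitrogen all stand beyond the scatter from compound 1 and within it of one another. Nothing available here offers an explanation for this pattern. The compounds shown leave open how a benzyl group, a longer alkyl chain, or a chain ending in an amine or a carboxylic acid would read on this nitrogen. They also leave open whether any group there can reach the level of compound 1.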